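A few compounds are considered here, and "the series" means these few. Any claim that something is new, unique, unknown or untested is made for them only; others in the source may bear on it.

In a functional assay on A549 cells (Homo sapiens) for cytotoxicity, read by MTT assay, with a stated time of 72 h (a higher number here means a weaker inhibitor, a lower number a stronger inhibitor), compound 1 `COc1cc2c(Oc3ccc(NC(=O)c4nnn(-c5ccc(F)cc5)c4C(F)(F)F)cc3F)ccnc2cc1OCCCN1CCC(C)CC1` gives 120 nM. Compound 2 `COc1cc2c(Oc3ccc(NC(=O)c4nnn(-c5ccc(C)cc5)c4C(F)(F)F)cc3F)ccnc2cc1OCCCN1CCC(C)CC1` carries a methyl in place of the fluoro on the aromatic carbon, and in this assay compound 2 gives 400 nM. Going by the values given here, that single change brings a 3.3-fold higher number from compound 1 to compound 2 (0.52 log units; beyond the scatter), so compound 2 stands highest of the two numbers known here, with compound 1 the only neighbour.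

Compound 3 `COc1cc2c(Oc3ccc(NC(=O)c4nnn(-c5ccccc5C(F)(F)F)c4C(F)(F)F)cc3F)ccnc2cc1OCCCN1CCC(C)CC1` is the next step from compound 2: 2-(trifluoromethyl)phenyl in place of 4-methylphenyl on an aromatic nitrogen. Among the compounds with values here, the only measured step that touches this ring is the one from compound 1 to compound 2, a modest rise, and it concerns a different group in a different place on that ring, so it gives a direction only loosely. Nothing measured shows what a trifluoromethyl on this ring does. The expectation is therefore a number close to that of compound 2, with wide uncertainty either way; the expected step is a 1.3-fold lower number from compound 2 to compound 3 (0.12 log units; within the scatter), within the scatter. On this basis compound 3 is estimated at 300 nM, in a range from 100 nM to 900 nM.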

Compound 3, half-maximal inhibitory concentration: 220 nM
Compound 3: middle estimate off by 1.4-fold (0.13 log units), on the high side; low and high end bracket the measured number.
By their numbers in this assay, from the lowest: compounds 1, 3 and 2 (each within the scatter of the next, the first and the last beyond it).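

The earlier compounds shown here placed only 4-fluorophenyl and 4-methylphenyl on this aromatic nitrogen of the five-membered ring. Compound 3 shows that 2-(trifluoromethyl)phenyl, with 10 heavy atoms against the 7 of 4-methylphenyl, also gives a number in the same range in this assay: there is a 1.8-fold lower number from compound 2 to compound 3 (0.26 log units; within the scatter), and there is a 1.8-fold higher number from compound 1 to compound 3 (0.26 log units; within the scatter). Compound 3 therefore cannot be ranked against either neighbour, even though the two earlier compounds are separated by more than the scatter, and no measurement here bears on why these numbers fall as they do.

Compound 3 differs from compound 2 both in the group carried by the phenyl ring and in where that group sits, so the compounds shown cannot separate the effect of the group from the effect of its place. From the compounds shown here alone, what a plain phenyl, or a phenyl carrying an amine or a carboxylic acid, would give on this nitrogen remains open, as does whether larger groups here would still leave the number in this range.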